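Swapping the aryl group on the isoxazoline-fused core

This account rests on a few compounds, and the source may have more. Where it says the series, first, only, none or still open, it means among the compounds named here.

Measured so far in a functional assay on DU-145 cells (Homo sapiens) for cytotoxicity, read by sulforhodamine B assay, with a stated time of 48 h; a higher number here means a weaker inhibitor, a lower number a stronger inhibitor:
compound 1 `C[C@H]1CC[C@@H]2[C@@H](OC(=O)[C@]23CC(c2c(Cl)cccc2Cl)=NO3)[C@]2(C)C(=O)C=C[C@@]12O` gives 38000 nM;
compound 2 `COc1ccc(C2=NO[C@]3(C2)C(=O)O[C@@H]2[C@H]3CC[C@H](C)[C@]3(O)C=CC(=O)[C@@]23C)cc1OC` gives 84000 nM;
compound 3 `COc1cc(C2=NO[C@]3(C2)C(=O)O[C@@H]2[C@H]3CC[C@H](C)[C@]3(O)C=CC(=O)[C@@]23C)ccc1O` gives 71000 nM.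

Among these three numbers, compound 2 gives the highest. Its step to compound 3 is within the scatter, a 1.2-fold lower number from compound 2 to compound 3 (0.07 log units; within the scatter), whereas the step of a 2.2-fold higher number from compound 1 to compound 2 (0.34 log units; beyond the scatter) lies beyond it. Compound 4 `C[C@H]1CC[C@@H]2[C@@H](OC(=O)[C@]23CC(c2ccc(F)cc2)=NO3)[C@]2(C)C(=O)C=C[C@@]12O` differs from compound 2 at one place: 4-fluorophenyl in place of 3,4-dimethoxyphenyl on a carbon with a double bond to nitrogen.

Within the data shown here, two measured steps bear on this change: a 2.2-fold higher number from compound 1 to compound 2 (0.34 log units; beyond the scatter) and a 1.9-fold higher number from compound 1 to compound 3 (0.27 log units; within the scatter). Each of them also swaps the group on the carbon with a double bond to nitrogen. Going by these compounds, both are modest, and neither involves 4-fluorophenyl, so its own effect is unknown. A step of at most a modest size in this assay seems likely, pointing back toward a lower number like that of compound 1, though a result within the scatter of compound 2 would not surprise.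

Compound 4 is therefore expected to give 50000 nM, with a range from 20000 nM to 120000 nM. That estimate means a step of a 1.7-fold lower number from compound 2 to compound 4 (0.23 log units; within the scatter).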

Compound 4, half-maximal inhibitory concentration: 13000 nM
The estimate for compound 4 lay 3.8-fold (0.59 log units) above the measured number; the whole stated range lies above it.
By their numbers in this assay, from the lowest: compound 4; then compounds 1, 3 and 2 (each within the scatter of the next, the first and the last beyond it).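

The earlier swaps on the carbon with a double bond to nitrogen moved the number in this assay only slightly, and this position looked fairly insensitive to the choice of aryl group. The 4-fluorophenyl group changes that picture, with a 6.5-fold lower number from compound 2 to compound 4 (0.81 log units; beyond the scatter), a 5.5-fold lower number from compound 3 to compound 4 (0.74 log units; beyond the scatter) and a 2.9-fold lower number from compound 1 to compound 4 (0.47 log units; beyond the scatter), which makes compound 4 the strongest of the four and shows that this position can shift cytotoxicity by more than the first three compounds suggested. Nothing measured here explains why the number falls.

Still open, going by these compounds, is whether the fluorine itself matters or whether a smaller, less substituted aryl group would do as well. A plain phenyl, a 4-chlorophenyl or a 4-aminophenyl on the same carbon would help separate these possibilities.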